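A few compounds are considered here, and "the series" means these few. Any claim that something is new, unique, unknown or untested is made for them only; others in the source may bear on it.

Compound 1 `CC(O)(CSc1cccc(C(F)(F)F)c1)C(=O)Nc1ccc(S(F)(F)(F)(F)F)cc1` and compound 2 `CC(O)(CSc1cccc(OC(F)(F)F)c1)C(=O)Nc1ccc(S(F)(F)(F)(F)F)cc1` share one core and differ in a single place: trifluoromethoxy in place of trifluoromethyl on an aromatic carbon. In a functional assay on VCaP cells (Homo sapiens) for antiproliferative activity, read by propidium iodide staining, with a stated time of 96 h (a higher number here means a weaker inhibitor, a lower number a stronger inhibitor), compound 1 gives 18800 nM, and compound 2 gives 13800 nM; that change made a 1.4-fold lower number from compound 1 to compound 2 (0.13 log units; within the scatter). Compound 3 `CC(O)(COc1cccc(C(F)(F)F)c1)C(=O)Nc1ccc(S(F)(F)(F)(F)F)cc1` is built on a different core; how its core differs from that of compound 1 is not broken down here. In this assay compound 3 gives 24700 nM. Compound 4 `CC(O)(COc1cccc(OC(F)(F)F)c1)C(=O)Nc1ccc(S(F)(F)(F)(F)F)cc1` has not been measured and differs from compound 3 by the same change: trifluoromethoxy in place of trifluoromethyl on an aromatic carbon. Among the compounds with values here, the measured example of this change stayed within the usual scatter, which is the only guide available. Compound 4 is therefore expected to show a step of about a 1.4-fold lower number from compound 3 to compound 4 (0.14 log units; within the scatter). That expectation rests on the starting point, because compound 3 gives 24700 nM, and on the measured pair, because the earlier change made a 1.4-fold lower number from compound 1 to compound 2 (0.13 log units; within the scatter). The estimate for compound 4 is 18000 nM, with a likely range from 8000 nM to 40000 nM.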

Compound 4, half-maximal inhibitory concentration: 18300 nM
Beside the measured number, compound 4's estimate is 1.0-fold (0.01 log units) below it; low and high end bracket the measured number.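

In this assay, putting trifluoromethoxy in place of trifluoromethyl made a 1.3-fold lower number from compound 3 to compound 4 (0.13 log units; within the scatter). Within the data shown here, the step on the second core matches the step on the first, so in these two pairs the change carried over from one core to the other: the same change on two cores in this assay, a 1.4-fold lower number (0.13 log units; within the scatter) from compound 1 to compound 2 and a 1.3-fold lower number (0.13 log units; within the scatter) from compound 3 to compound 4, 1.0-fold (0.00 log units) apart, within the scatter of two such steps Each step lies within the scatter, however, so this agreement shows only that the change made little measurable difference on both cores, not that it reliably lowers the number, and two cores say nothing about any others.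

The compounds shown leave open what a quite different group at this place on the aromatic ring, such as an amine, a carboxylic acid or a longer chain, would do. They also leave open whether such a group's step would carry over between these cores.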